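Swapping a chloro for a methyl on a hydrazone series

The source may hold more compounds than are shown below. What is called first, only, known or untested is meant among the compounds shown, and "the series" means these compounds.

Of the compounds shown here, three that share one core have been tested in a functional assay on the whole organism for inhibition, with Rattus norvegicus as the target; on this read-out higher numbers stand for an effect only at larger amounts of compound and lower numbers for an effect already at smaller amounts. Compound 1 `CC1C/C(=N\Nc2ccccc2)c2ncc(C(=O)O)c(=O)n2C1` reaches only the limit of the assay, giving > 320 umol/kg. Compound 2 `CC1CC/C(=N\Nc2cccc(Cl)c2)c2ncc(C(=O)O)c(=O)n21` also stops at a limit, giving > 100 umol/kg. Compound 3 `CCOc1ccc(N/N=C2\CC[C@H](C)n3c2ncc(C(=O)O)c3=O)cc1` likewise ends at a limit, giving > 100 umol/kg. For the measured compounds named here, none of the three therefore has a number of its own, so no steps between measured compounds can be drawn; compound 2 simply sits at the limit of > 100 umol/kg in this assay, at which 2 of the 3 values shown sit, while compound 1 sits at the limit of > 320 umol/kg in this assay, at which 1 of the 3 values shown sits.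

Compound 4 `Cc1cccc(N/N=C2\CCC(C)n3c2ncc(C(=O)O)c3=O)c1` has not yet been measured. It differs from compound 2 in one place: methyl in place of chloro on an aromatic carbon. With every neighbour at a limit, the change is expected to move the read-out by no more than the usual scatter, so the expected step that the limit leaves unreadable from compound 2 to compound 4 is small and carries no clear direction. Compound 4 is therefore estimated at 200 umol/kg in this assay, within a range from 60 umol/kg to 1000 umol/kg, and most likely it too will be reported only as a limit.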

Compound 4, dose for 50% inhibition: 72.5 umol/kg
For compound 4 the middle estimate is 2.8-fold (0.44 log units) above the measured one, within the range that was stated.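

For the compounds shown here, compound 4 is the first compound here to give a number of its own rather than a limit in this assay, so this core can show an effect within the doses tested. The change from 3-chlorophenyl to 3-methylphenyl gives an at least 1.3-fold lower number from compound 2 to compound 4 (0.13 log units; that floor lies within the scatter), which means that the part of the step that can be secured does not stand clear of ordinary repeat variation. The true size of the step remains unknown because compound 2 has only a limit: the limit of > 100 umol/kg in this assay, at which 2 of the 4 values shown sit.

A single pair cannot show how far this result extends to other groups on the same aromatic carbon. An ethyl, a methoxy or an amine there would test whether the effect is particular to methyl or is shared more widely.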